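A few compounds are considered here, and "the series" means these few. Any claim that something is new, unique, unknown or untested is made for them only; others in the source may bear on it.

Measured so far in an ADME assay on C8166 cells (Homo sapiens) for cytotoxicity, read by MTT assay; on this read-out lower numbers stand for higher toxicity in this test and higher numbers for lower toxicity in this test:
- compound 1 `CCCn1cc(C(=O)O)c(=O)c2c(O)c(Cc3cccc(Cl)c3F)ccc21`: 24200 nM
- compound 2 `CCCCn1cc(C(=O)O)c(=O)c2c(O)c(Cc3cccc(Cl)c3F)ccc21`: 20000 nM

With only these two compounds measured, compound 2 at 20000 nM lies within the scatter of compound 1, so the pair cannot be ranked. Both compounds share the same core and differ only in the chain on the aromatic nitrogen.

The next compound, compound 3 `CCCCCn1cc(C(=O)O)c(=O)c2c(O)c(Cc3cccc(Cl)c3F)ccc21`, differs from compound 2 by methyl in place of hydrogen on a saturated chain carbon, four bonds along the chain from an aromatic nitrogen. This places methyl in place of hydrogen on a saturated chain carbon, four bonds along the chain from an aromatic nitrogen.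

Among the measured compounds shown here, one measured step bears on this change: the same replacement three bonds along the chain from an aromatic nitrogen, a 1.2-fold lower number from compound 1 to compound 2 (0.08 log units; within the scatter). A single step within the scatter is thin evidence, and it gives no firm direction. On that basis, no change beyond the scatter is expected in this assay.

The expected size is a 1.1-fold lower number from compound 2 to compound 3 (0.05 log units; within the scatter). For compound 3 the estimated value is 18000 nM, with an expected range from 10000 nM to 32000 nM.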

Compound 3, half-maximal cytotoxic concentration: 39900 nM
The estimate for compound 3 lay 2.2-fold (0.35 log units) below the measured number; the measured number lies above the stated range.
By their numbers in this assay, from the lowest: compounds 2, 1 and 3 (each within the scatter of the next).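

In this assay, methyl in place of hydrogen on a saturated chain carbon, four bonds along the chain from the aromatic nitrogen, gives a 2.0-fold higher number from compound 2 to compound 3 (0.30 log units; within the scatter) and adds a second reading at this chain to the one three bonds along. Ethyl in place of hydrogen three bonds along the chain gives a 1.6-fold higher number from compound 1 to compound 3 (0.22 log units; within the scatter), so even the widest chain change shown stays within the usual scatter, and none of the three chains on the aromatic nitrogen can be set apart from the others in this test. Nothing measured here gives a reason for these numbers.

As far as these compounds go, whether the number in this assay would move beyond the scatter with a longer chain on the aromatic nitrogen remains open. So does the reading for a chain of another kind at this place, such as one ending in an amine, a hydroxyl group or a phenyl ring, since every chain shown is a plain saturated one.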